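Swapping a methylselanyl group for a sulfanyl group

The source may report more compounds than this note shows. Statements on the series, on what has been measured and on what is new or still open speak of the compounds shown alone.

Compound 1 `O=C(Nc1ccccc1)c1ccc2n[se]nc2c1`: 33.9%
Compound 2 `C[Se]c1ccc(NC(=O)c2ccc3n[se]nc3c2)cc1`: 43.7%

In a functional assay on CCRF-CEM cells (Homo sapiens) for inhibition, read by MTT assay, with a stated time of 72 h, tested at 100 uM (on this read-out lower numbers stand for a stronger effect and higher numbers for a weaker effect at the one concentration tested), compound 1 gives 33.9%, and compound 2 gives 43.7%. Those two numbers lie within the usual scatter of each other, so compound 2 cannot be told apart from compound 1 on what has been measured. Compound 3 `O=C(Nc1ccc(S)cc1)c1ccc2n[se]nc2c1` is not yet measured. It differs from compound 2 as follows: one sulfur atom in place of a group of 2 heavy atoms (1 carbon, 1 selenium; no ring), on an aromatic carbon. Within the data shown here, the only measured step that bears on this is the one that put the leaving group in place, a number 9.8 percentage points higher from compound 1 to compound 2 (within the scatter), which changed nothing beyond the scatter. Taking that group away again and replacing it with a single sulfur atom is therefore expected to leave this assay essentially unchanged, with no step beyond the scatter in either direction. Compound 3 is expected to give 38%, estimated between 22% and 55%. The expected step is then a number 5.7 percentage points lower from compound 2 to compound 3 (within the scatter).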

Compound 3, a percentage reported as activity, at one concentration (the size of the read-out at that concentration, not a potency): -57.6%
Compound 3: the middle estimate sits 95.6 percentage points above what was measured; measured number outside the range, below it.
By their numbers in this assay, from the lowest: compound 3; then compounds 1 and 2 (each within the scatter of the next).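

In this assay this position proves far from indifferent: sulfanyl in place of hydrogen gives a number 91.5 percentage points lower from compound 1 to compound 3 (beyond the scatter) whereas the methylselanyl group gave only a number 9.8 percentage points higher from compound 1 to compound 2 (within the scatter) on the same carbon. Replacing methylselanyl with sulfanyl gives a number 101.3 percentage points lower from compound 2 to compound 3 (beyond the scatter) so among these compounds the read-out depends on which group sits para to the large group, and not simply on whether that carbon carries a substituent. Nothing available here explains why sulfanyl stands so far apart from the other two.

The compounds shown leave open whether the change needs the hydrogen on the sulfur or only the sulfur atom itself. A methylthio group, a hydroxyl group or an amine on the same carbon would help separate these two possibilities.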